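A few compounds are considered here, and "the series" means these few. Any claim that something is new, unique, unknown or untested is made for them only; others in the source may bear on it.

In an ADME assay on MRC5 cells (Homo sapiens) for inhibition, with a stated time of 72 h (a lower number here means that less compound is needed, a higher number that more compound is needed for the effect), compound 2 `CO[C@H]1CC[C@H](NC(=O)c2n[nH]cc2NC(=O)c2ccccc2)CC1` gives 800 nM and holds the lowest number available here. Compound 1 `CCc1ccccc1C(=O)Nc1c[nH]nc1C(=O)N[C@H]1CC[C@H](OC)CC1` gives 3400 nM in the same test. For compound 3 `CO[C@H]1CC[C@H](NC(=O)c2n[nH]cc2NC(=O)c2ccc(N3CCCC3)cc2)CC1` the result > 50000 nM is a limit of the assay and not a number.

Compound 4 `CO[C@H]1CC[C@H](NC(=O)c2n[nH]cc2NC(=O)c2ccccc2C(F)(F)F)CC1` has not been measured yet. Compared with compound 2, it carries trifluoromethyl in place of hydrogen on an aromatic carbon, ortho to a large group (trifluoromethyl in place of hydrogen on an aromatic carbon).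

Going by the values given here, two measured steps bear on this change. Hydrogen in place of ethyl gave a modest step (a 4.3-fold lower number from compound 1 to compound 2 (0.63 log units; beyond the scatter)), so a new group on that ring of compound 2 may raise the number by a similar amount. Pyrrolidin-1-yl in place of hydrogen gave a large step (an at least 62-fold higher number from compound 2 to compound 3 (1.79 log units; beyond the scatter)), but trifluoromethyl brings no ring, so this is the weaker guide.

A modest rise in this assay is therefore expected, close to the ethyl case. The estimated step is (a 3.1-fold higher number from compound 2 to compound 4 (0.49 log units; beyond the scatter)). The expected value for compound 4 is 2500 nM with an estimated range (800 nM to 8000 nM).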

Compound 4, half-maximal effective concentration: 3300 nM
For compound 4 the middle estimate is 1.3-fold (0.12 log units) below the measured one; low and high end bracket the measured number.
By their numbers in this assay, from the lowest: compound 2; then compounds 4 and 1 (each within the scatter of the next). At a limit, above all of these: compound 3.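

In this assay, trifluoromethyl on an aromatic carbon ortho to a large group gives a 4.1-fold higher number from compound 2 to compound 4 (0.62 log units; beyond the scatter), so ethyl is no longer the only group shown at this place that goes with a number beyond the scatter of the unsubstituted compound 2. Ethyl and trifluoromethyl at this place cannot be told apart in this test, with a 1.0-fold lower number from compound 1 to compound 4 (0.01 log units; within the scatter), although the two groups differ in their atoms. Nothing measured here bears on why a change of hydrogen to either group goes with this rise.

Still open, going by these compounds, is whether a single fluorine or chlorine atom, or a methoxy group, on this same carbon would give a number close to those of compound 1 and compound 4. A carboxylic acid or a primary amine at this place could also behave differently from both groups.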